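The source may report more compounds than this note shows. Statements on the series, on what has been measured and on what is new or still open speak of the compounds shown alone.

Of the compounds shown here, three sharing one core have so far been tested in a functional assay on PC-9 cells (Homo sapiens) for inhibition, read by MTT assay, with a stated time of 48 h, tested at 10 uM; a lower number here means less inhibition, a higher number more inhibition at the concentration tested (going by the name of the read-out). Compound 1 `COc1cc(NC(=O)Nc2cc(Nc3ccc(C)c(C)c3)ncn2)cc(OC)c1` gives 66% in this assay, the lowest of the three numbers. Compound 3 `COc1ccc(C(F)(F)F)cc1Nc1cc(NC(=O)Nc2c(Cl)cccc2Cl)ncn1` gives 89% in this assay, and compound 2 `COc1cc(Br)ccc1Nc1cc(NC(=O)Nc2c(Cl)cccc2Cl)ncn1` gives 90.5% in this assay, each lying above compound 1 by a gap beyond the usual scatter of the measurement. Compounds 2 and 3 differ from compound 1 in several places at once, so their higher numbers cannot be tied to any single part of the structure.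

Compound 4 `COc1cc(NC(=O)Nc2cc(Nc3cc(C)cc(F)c3)ncn2)cc(OC)c1` has not yet been measured. It differs from compound 1 in one place only: 3-fluoro-5-methylphenyl in place of 3,4-dimethylphenyl on a nitrogen on an aromatic ring. The groups that leave and enter are of the same size, each a single six-membered aromatic ring of carbon only, with no donors or acceptors on either side of the change.

Within the data shown here, no pair of measured compounds differs in just one place, so there is no earlier single step to compare with. On that basis the step from compound 1 to compound 4 a number 2 percentage points lower from compound 1 to compound 4 (within the scatter) is expected to be small, in no clear direction, and not beyond the scatter. Compound 4 is therefore estimated to give about 64% in this assay, with a likely range from 48% to 78%.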

Compound 4, a percentage reported as inhibition, at one concentration (the size of the read-out at that concentration, not a potency): 64.5%
Compound 4: the middle estimate sits 0.5 percentage points below what was measured, and the stated range covers the measured number.
By their numbers in this assay, from the lowest: compounds 4 and 1 (each within the scatter of the next); then compounds 3 and 2 (each within the scatter of the next).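

Swapping 3,4-dimethylphenyl for 3-fluoro-5-methylphenyl on a nitrogen on an aromatic ring gives the first step in this assay that can be tied to one place in the structure: a number 1.5 percentage points lower from compound 1 to compound 4 (within the scatter). On the core of compound 1, then, this change of the groups on the six-membered ring produces no difference that can be told apart from the ordinary spread of repeated measurements, although this is a single exchange and a reading at one concentration, not a measure of potency. Nothing measured alongside these compounds bears on why the number holds steady.

Compounds 2 and 3 differ from compound 1 and compound 4 in several places at once, so this step does not show which part of their structures goes with their numbers. As far as these compounds go, it also remains open whether the number would hold with a different kind of group at this nitrogen, such as a ring carrying an amine or a carboxylic acid, or a longer chain in place of the ring.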